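A few compounds are considered here, and "the series" means these few. Any claim that something is new, unique, unknown or untested is made for them only; others in the source may bear on it.

Working notes on the series.

Two compounds have numbers in a functional assay on CHO cells for antagonist activity at prostaglandin E2 receptor EP3 subtype (Homo sapiens), read by cAMP accumulation; a lower number here means a stronger inhibitor, a higher number a weaker inhibitor. Compound 1 `CCn1ncc2c(F)cc(-c3ccc(C(CC)(CC)c4nnc[nH]4)c(=O)[nH]3)cc21` gives 29 nM in this assay. Compound 2 `CC(C)C(Nc1nccs1)c1ccc(-c2ccc3cccc(F)c3c2)[nH]c1=O` gives 10 nM in this assay. On these two numbers compound 1 stands highest; its nearest neighbour is compound 2, whose number is lower by an amount beyond the usual scatter. For the measured compounds named here, no pair of measured compounds differing in a single place is available, so no measured step can be quoted.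

Compound 3 `CCn1ncc2c(F)cc(-c3ccc(C(CC)(CC)c4ncn(C)n4)c(=O)[nH]3)cc21` has not yet been measured. It differs from compound 1 in one place: 1-methyl-1H-1,2,4-triazol-3-yl in place of 4H-1,2,4-triazol-3-yl on a saturated chain carbon bound to an aromatic carbon and two saturated chain carbons. The change removes the only hydrogen-bond donor of that ring and adds a methyl group. Nothing measured in the series shows what this does; the expectation is a modest weakening, a step from compound 1 to compound 3 of a 2.1-fold higher number from compound 1 to compound 3 (0.32 log units; beyond the scatter), though a step within the scatter cannot be excluded. Compound 3 is estimated at 60 nM, with a range from 20 nM to 200 nM.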

Compound 3, half-maximal inhibitory concentration: 96 nM
Beside the measured number, compound 3's estimate is 1.6-fold (0.20 log units) below it; measured number inside the range.
By their numbers in this assay, from the lowest: compound 2; then compound 1; then compound 3.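

At the saturated chain carbon bound to an aromatic carbon and two saturated chain carbons, 1-methyl-1H-1,2,4-triazol-3-yl in place of 4H-1,2,4-triazol-3-yl gives, in this assay, a 3.3-fold higher number from compound 1 to compound 3 (0.52 log units; beyond the scatter). For the compounds shown here, this is the first single-place step, and it shows that this position responds to the change: the entering group has 0 hydrogen-bond donors where the leaving group has 1, and it also carries the added methyl. No measured information separates these two differences or gives a reason for the step.

The compounds shown leave open whether the donor or the methyl accounts for the step. They also leave open how an ethyl group on the triazole, or a carboxylic acid in place of the triazole on that carbon, would read in this assay.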